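This account rests on a few compounds, and the source may have more. Where it says the series, first, only, none or still open, it means among the compounds named here.

Working notes on a small series built on one shared core. In a functional assay on OVCAR-5 cells (Homo sapiens) for inhibition, read by sulforhodamine B assay, with a stated time of 48 h (a lower number here means a stronger inhibitor of growth, a higher number a weaker inhibitor of growth), compound 1 `CCOC(=O)[C@H](CCC(=O)O)NC(=O)c1ccc(Sc2nc3cc(N)cc(N)c3nc2-c2ccccc2)cc1` gives 60300 nM. Compound 2 `Nc1cc(N)c2nc(-c3ccccc3)c(Sc3ccc(F)cc3)nc2c1` gives 19100 nM in this assay, and compound 3 `COc1cc(CNc2nc3cc(N)cc(N)c3nc2-c2ccccc2)cc(OC)c1OC` gives 21400 nM. Compound 2 carries the lowest of the three numbers; its number and that of compound 3 lie within the scatter of each other, whereas the number of compound 1 stands beyond it. Compound 4 `Nc1cc(N)c2nc(-c3ccccc3)c(Sc3ccc(Cl)c(Cl)c3)nc2c1` has not been measured in this assay. It differs from compound 2 in one place: 3,4-dichlorophenyl in place of 4-fluorophenyl on a sulfur. Going by the values given here, no measured pair in the set shows a change of this kind, so no step size can be read off. The change is expected to stay within the scatter, leaning if anything toward a lower number, and the step is estimated as a 1.4-fold lower number from compound 2 to compound 4 (0.13 log units; within the scatter). Compound 4 is expected to give about 14000 nM in this assay, with a range from 5000 nM to 40000 nM.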

Compound 4, concentration for 50% growth inhibition: 38900 nM
For compound 4 the middle estimate is 2.8-fold (0.44 log units) below the measured one; low and high end bracket the measured number.
By their numbers in this assay, from the lowest: compounds 2, 3, 4 and 1 (each within the scatter of the next, the first and the last beyond it).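

Going by these compounds alone, on the sulfur of the shared core, a single change can now be read for the first time: in this assay, 3,4-dichlorophenyl in place of 4-fluorophenyl gives a 2.0-fold higher number from compound 2 to compound 4 (0.31 log units; beyond the scatter), a modest step. The number at this position therefore responds to the aryl group on the sulfur, and this exchange does not lower it. No measurement at hand accounts for the step.

Going by these compounds, it remains open whether 4-chlorophenyl or plain phenyl on the same sulfur would stand with compound 2 or with compound 4. Also open, on these data alone, is how a carboxylic acid or an amine on that ring would read.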